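The compounds below may be only part of what the source reports. "The series", "measured", "known", "first", "only" and "open" are said of these compounds alone.

Measured so far:
compound 1 `Cc1cccc2ccn(CCCCN3CCN(C(c4ccccc4)c4ccccc4)CC3)c12` — 2300 nM
compound 2 `Fc1ccc2c(ccn2CCCCN2CCN(C(c3ccccc3)c3ccccc3)CC2)c1` — 120 nM

In an assay on RPMI-8226 cells for antagonist activity at P2X purinoceptor 7 (Homo sapiens), read by calcium flux (a lower number here means a stronger inhibitor, a higher number a weaker inhibitor), compound 2 gives 120 nM, the lowest of the two numbers. Compound 1 gives 2300 nM. Among the compounds with values here, the only measured step is a 19-fold lower number from compound 1 to compound 2 (1.28 log units; beyond the scatter), and it changes both which group sits on the fused ring and where it sits, so it does not separate the two effects.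

Compound 3 `Fc1ccc2ccn(CCCCN3CCN(C(c4ccccc4)c4ccccc4)CC3)c2c1` differs from compound 2 by 6-fluoro-1H-indol-1-yl in place of 5-fluoro-1H-indol-1-yl on a saturated chain carbon, four bonds along the chain from an amine nitrogen in a ring. Within the data shown here, no measured step keeps the fluorine and moves it alone, so a 19-fold lower number from compound 1 to compound 2 (1.28 log units; beyond the scatter) bears on this only loosely: it shows that a fluorinated ring of this kind can carry a low number, but gives no guide to which placing of the fluorine does so. The expected step of a 1.7-fold higher number from compound 2 to compound 3 (0.22 log units; within the scatter) is therefore small, quite possibly within the scatter, with wide uncertainty either way. Compound 3 is expected at 200 nM, in the range 60 nM to 700 nM.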

Compound 3, half-maximal inhibitory concentration: 110 nM
The estimate for compound 3 lay 1.8-fold (0.26 log units) above the measured number; measured number inside the range.
By their numbers in this assay, from the lowest: compounds 3 and 2 (each within the scatter of the next); then compound 1.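

In this assay, the step between the two fluorine placings is a 1.1-fold lower number from compound 2 to compound 3 (0.04 log units; within the scatter), so these data do not tell 6-fluoro-1H-indol-1-yl from 5-fluoro-1H-indol-1-yl. The step of a 21-fold lower number from compound 1 to compound 3 (1.32 log units; beyond the scatter) stands with the earlier step of a 19-fold lower number from compound 1 to compound 2 (1.28 log units; beyond the scatter), so the gap from 7-methyl-1H-indol-1-yl does not depend on the 5-fluoro placing alone. No available evidence bears on why the two fluorine placings read alike.

The compounds shown leave open whether the gap from compound 1 follows from replacing the methyl group with fluorine or from the different placing, which 7-fluoro-1H-indol-1-yl or 6-methyl-1H-indol-1-yl would help separate. Also open, on these data alone, is how a nitrile or a methoxy group would read in place of the fluorine, and how a longer chain would read.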